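A few compounds are considered here, and "the series" means these few. Any claim that something is new, unique, unknown or untested is made for them only; others in the source may bear on it.

Measured so far in a functional assay on MDA-MB-231 cells (Homo sapiens) for antiproliferative activity, read by MTT assay, with a stated time of 48 h; a lower number here means a stronger inhibitor, a higher number a weaker inhibitor:
- compound 1 `C=CS(=O)(=O)N1CCN(c2ncnc3sc(-c4ccc(N5CCN(C)CC5)cc4)cc23)CC1`: 7550 nM
- compound 2 `CN1CCN(c2ccc(-c3cc4c(N5CCN(S(=O)(=O)C6CC6)CC5)ncnc4s3)cc2)CC1`: 11500 nM
- compound 3 `COc1ccc(NC(=O)N2CCN(c3ncnc4sc(-c5ccc(N6CCN(C)CC6)cc5)cc34)CC2)cc1`: 20900 nM

Among the compounds with values here, only one gap around compound 3 exceeds the scatter: a 2.8-fold higher number from compound 1 to compound 3 (0.44 log units; beyond the scatter), set against a 1.8-fold higher number from compound 2 to compound 3 (0.26 log units; within the scatter). The sulfonyl swap, a 1.5-fold higher number from compound 1 to compound 2 (0.18 log units; within the scatter), also stays within the scatter.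

Compound 4 `CN1CCN(c2ccc(-c3cc4c(N5CCN(C(=O)Nc6ccc(OC(F)(F)F)cc6)CC5)ncnc4s3)cc2)CC1` keeps everything in compound 3 except one group: trifluoromethyl in place of methyl on an oxygen on an aromatic ring. Within the data shown here, no measured step touches this site. All three steps concern the group on the amine nitrogen in a ring, so they bear on it only indirectly, as a guide to how far values have moved in this small set. The largest of them is modest, a 2.8-fold higher number from compound 1 to compound 3 (0.44 log units; beyond the scatter), and the change here is confined to the end of the (4-methoxyphenyl)carbamoyl group. The step expected in this assay is a 1.2-fold lower number from compound 3 to compound 4 (0.06 log units; within the scatter), so no move beyond the scatter is expected, in either direction. Compound 4 is estimated at 18000 nM, with an expected range of 7000 nM to 40000 nM.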

Compound 4, half-maximal inhibitory concentration: 4600 nM
Compound 4: middle estimate off by 3.9-fold (0.59 log units), on the high side; measured number outside the range, below it.
By their numbers in this assay, from the lowest: compounds 4, 1, 2 and 3 (each within the scatter of the next, the first and the last beyond it).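

In this assay, the end of the (4-methoxyphenyl)carbamoyl group proves to be a site that responds: methoxy to trifluoromethoxy gives a 4.5-fold lower number from compound 3 to compound 4 (0.66 log units; beyond the scatter), with the oxygen on the aromatic ring kept and only methyl replaced by trifluoromethyl. Within the data shown here, every earlier step concerned the group on the amine nitrogen in a ring, so this is the first reading at this site, and it shows that a change confined to the end of that group can move the number beyond the scatter. Nothing measured here explains the step.

From the compounds shown here alone, this rests on one pair, so it remains unknown whether the step is specific to trifluoromethyl. An ethyl or difluoromethyl group on the same oxygen, or a chlorine replacing the whole trifluoromethoxy group, would test that.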